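Methoxy in Place of Chloro: What to Expect

This account rests on a few compounds, and the source may have more. Where it says the series, first, only, none or still open, it means among the compounds named here.

Compound 1 `O=C(/C=C\Nc1ccc(Cl)cc1)c1cn(-c2ccccc2)nc1-c1ccc(F)cc1`: 4600 nM
Compound 2 `O=C(/C=C\Nc1ccc(Cl)cc1)c1cn(-c2ccccc2)nc1-c1ccc(Cl)cc1`: 4650 nM

In a functional assay on HT-29 cells (Homo sapiens) for antiproliferative activity, read by MTT assay, with a stated time of 48 h (on this read-out lower numbers stand for stronger inhibition and higher numbers for weaker inhibition), compound 1 gives 4600 nM. Compound 2 gives 4650 nM in this assay, the higher of the two numbers, though the step of a 1.0-fold higher number from compound 1 to compound 2 (0.00 log units; within the scatter) is within the scatter, so the two compounds cannot be told apart. Compound 3 `COc1ccc(-c2nn(-c3ccccc3)cc2C(=O)/C=C\Nc2ccc(Cl)cc2)cc1` differs from compound 2 by methoxy in place of chloro on an aromatic carbon. Within the data shown here, no measured step swaps chloro for methoxy; the only step seen, from fluoro to chloro, showed no change beyond the scatter. Compound 3 is therefore expected to show a step of a 1.0-fold lower number from compound 2 to compound 3 (0.01 log units; within the scatter), an estimate of 4500 nM with a range from 1800 nM to 11000 nM.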

Compound 3, half-maximal inhibitory concentration: 4760 nM
Estimate against measurement, compound 3: 1.1-fold (0.02 log units) below; the range from low to high includes it.
By their numbers in this assay, from the lowest: compounds 1, 2 and 3 (each within the scatter of the next).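

In this assay two steps now reach methoxy on this aromatic carbon: chloro to methoxy (a 1.0-fold higher number from compound 2 to compound 3 (0.01 log units; within the scatter)) and fluoro to methoxy (a 1.0-fold higher number from compound 1 to compound 3 (0.01 log units; within the scatter)). The position, para to a large group, therefore takes a two-atom group with a hydrogen-bond acceptor as well as a single halogen atom, and the three compounds still cannot be told apart. Nothing available explains why these groups read alike.

The compounds shown leave open whether an amine, a carboxylic acid or a longer chain here would move the number beyond the scatter.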